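Carbamate in place of thiocarbamate on a nucleoside series

This account rests on a few compounds, and the source may have more. Where it says the series, first, only, none or still open, it means among the compounds named here.

Measured compounds:
Compound 1, `C/N=C(\S)OC[C@H]1OC(n2cnc3c(NC4CCOC4)ncnc32)[C@H](O)[C@@H]1O`, 45 nM
Compound 2, `CC(C)/N=C(\S)OC[C@H]1OC(n2cnc3c(NC4CCOC4)ncnc32)[C@H](O)[C@@H]1O`, 36 nM

Both compounds were tested in an assay on DDT1 cells (Cricetulus griseus) for binding affinity to adenosine receptor A1 (Homo sapiens), read by radioligand binding; a lower number here means a stronger inhibitor, a higher number a weaker inhibitor. Compound 1 gives 45 nM and compound 2 gives 36 nM. For the measured compounds named here, the one measured step, a 1.3-fold lower number from compound 1 to compound 2 (0.10 log units; within the scatter), concerns the group on the double-bonded nitrogen of the thiocarbamate; it stays within the scatter. Compound 2 shows the lowest of the two numbers, but its gap to compound 1 is within the scatter, so no order can be read between them.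

Compound 3, `O=C(NC1CCC1)OC[C@H]1OC(n2cnc3c(NC4CCOC4)ncnc32)[C@H](O)[C@@H]1O`, has not been measured in this assay. It differs from compound 2 at the same end of the molecule: a group of 7 heavy atoms (5 carbon, 1 nitrogen, 1 oxygen; one four-membered non-aromatic ring of carbon only) in place of a group of 6 heavy atoms (4 carbon, 1 nitrogen, 1 sulfur; no ring), on an oxygen on a saturated carbon. Going by the values given here, the only measured step bearing on this region was within the scatter, and no measured pair covers an exchange of sulfur for oxygen in this group. The expected step from compound 2 to compound 3 is therefore small, a 1.3-fold higher number from compound 2 to compound 3 (0.10 log units; within the scatter), with no direction beyond the scatter. Compound 3 is estimated at 45 nM, within a range from 15 nM to 140 nM.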

Compound 3, inhibition constant: 306 nM
The estimate for compound 3 lay 6.8-fold (0.83 log units) below the measured number, and the stated range ends below it.
By their numbers in this assay, from the lowest: compounds 2 and 1 (each within the scatter of the next); then compound 3.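

Cyclobutylcarbamoyl entering on the oxygen on a saturated carbon gave an 8.5-fold higher number from compound 2 to compound 3 (0.93 log units; beyond the scatter) and a 6.8-fold higher number from compound 1 to compound 3 (0.83 log units; beyond the scatter) in this assay, so this end of the molecule, which had shown no readable change with the exchange on the double-bonded nitrogen, does respond to substitution. Both of these steps lie beyond the scatter, but each brings oxygen in place of sulfur and a four-membered ring in place of a group with no ring at once, so the two exchanges cannot be told apart. Nothing measured here gives a cause for the higher number of compound 3.

Still open, as far as these compounds go, is whether a thiocarbamate carrying cyclobutyl would stay with compound 1 and compound 2, or whether a carbamate carrying methyl or isopropyl would stay with compound 3. From the compounds shown here alone, how an amine or a longer chain would read in this group also remains open.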